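Swapping a thiophene for a dichlorophenyl on the oxadiazole

This account rests on a few compounds, and the source may have more. Where it says the series, first, only, none or still open, it means among the compounds named here.

Compound 1 `Cn1ncc2c(c1=O)Oc1ccccc1C1=NCCN12`: gives only a limit, > 100000 nM, in an assay for inhibition of Amine oxidase [flavin-containing] A (Homo sapiens), read by fluorescence and spectrophotometry, using microsomes, with stated times of 30 min and 20 min; a lower number here means a stronger inhibitor, a higher number a weaker inhibitor
Compound 2 `Cc1ccc(-c2nc(-c3ccc(C4=NCCN4)cc3)no2)cc1`: 2310 nM in this assay
Compound 3 `c1csc(-c2noc(-c3ccc(C4=NCCN4)cc3)n2)c1`: 1570 nM in this assay

Among the two numbers that were actually read, compound 3 has the lower one. Compound 2, which carries a methyl-substituted phenyl in the place where compound 3 carries a thiophene, sits close enough that the gap lies within the usual scatter, so the two cannot be ranked. Compound 1, built on a different core, gives no number at all; its value is a limit of the assay (the limit of > 100000 nM in this assay, at which 1 of the 3 values shown sits).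

Compound 4 `Clc1ccc(-c2noc(-c3ccc(C4=NCCN4)cc3)n2)cc1Cl` differs from compound 3 in one place: 3,4-dichlorophenyl in place of thiophen-2-yl on an aromatic carbon. Among the measured compounds shown here, no measured pair shows what such a swap does here, so the expectation rests on the fact that two different aryl groups at this position, in compound 2 and compound 3, gave numbers within scatter of each other. A small change, if any, is expected in this assay, with a slight lean toward a lower number. Compound 4 is therefore estimated at about 1000 nM, within a range from 300 nM to 4000 nM. This estimate corresponds to a step of a 1.6-fold lower number from compound 3 to compound 4 (0.20 log units; within the scatter), which is not expected to clearly exceed the scatter.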

Compound 4, half-maximal inhibitory concentration: 1110 nM
Beside the measured number, compound 4's estimate is 1.1-fold (0.05 log units) below it; the measured number falls inside the stated range.
By their numbers in this assay, from the lowest: compounds 4, 3 and 2 (each within the scatter of the next, the first and the last beyond it). At a limit, above all of these: compound 1.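

Read in this assay, the swap gives a 1.4-fold lower number from compound 3 to compound 4 (0.15 log units; within the scatter), and this is the first step between two compounds that differ only at this carbon of the five-membered ring. The change is not a small one on paper: 3,4-dichlorophenyl brings 8 heavy atoms and 0 hydrogen-bond acceptors, where thiophen-2-yl has 5 heavy atoms and 1 hydrogen-bond acceptor, and it replaces sulfur in the ring with two chlorine atoms on a ring of carbon only. Even so, the two compounds cannot be told apart in this measurement, so for this pair the position accepts the larger ring with no readable change, and nothing available gives a cause for that result.

As far as these compounds go, what an amine, a carboxylic acid or a longer chain would do on this carbon stays open, since both groups compared here are aromatic rings with no net charge. Also open, from the compounds shown here alone, is what a phenyl ring with a single chlorine, or with none, would show, and whether any group at this position can move the number beyond the usual scatter.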